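Shifting the Methoxy Group: Compound 2 to Compound 4

The source may report more compounds than this note shows. Statements on the series, on what has been measured and on what is new or still open speak of the compounds shown alone.

Of the compounds shown here, three built on one shared core have been tested, each differing at the amine nitrogen in a ring and on the aromatic ring of the core. In a functional assay on the whole organism (strain Wistar) with Rattus norvegicus as the target, with a stated time of 5 min (on this read-out lower numbers stand for an effect already at smaller amounts and higher numbers for an effect only at larger amounts of compound), compound 1 `CCC1(CCCCN2CCN(c3cccc(Cl)c3)CC2)C(=O)Nc2c(Cl)cc(Cl)cc21` reaches only the limit of > 20 mg/kg. Compound 3 `CCC1(CCCCN2CCN(c3ccc(F)cc3)CC2)C(=O)Nc2ccc(F)cc21` likewise reaches only the limit of > 20 mg/kg. Among the measured compounds shown here, compound 2 `CCC1(CCCCN2CCN(c3ccc(OC)cc3)CC2)C(=O)Nc2ccccc21` also stops at the limit of > 20 mg/kg, so its standing is set by the limit of > 20 mg/kg in this assay, at which 3 of the 3 values shown sit, alone: no compound can be ranked above another. Compound 4 `CCC1(CCCCN2CCN(c3ccccc3OC)CC2)C(=O)Nc2ccccc21` carries 2-methoxyphenyl in place of 4-methoxyphenyl on an amine nitrogen in a ring. For the measured compounds named here, no measured pair separates these two groups, so the data give no direction for the step. Compound 4 is expected to come out near 25 mg/kg, between 10 mg/kg and 60 mg/kg, most likely again as a limit. The expected step that the limit leaves unreadable from compound 2 to compound 4 is none beyond the scatter.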

Compound 4, minimum effective dose: 10 mg/kg
Estimate against measurement, compound 4: 2.5-fold (0.40 log units) above, within the range that was stated.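

Placing the methoxy group as 2-methoxyphenyl gives the only reading on the shared core that is not a limit: in this assay compound 4 gives 10 mg/kg. The change at this position is an at least 2.0-fold lower number from compound 2 to compound 4 (0.30 log units; that floor lies within the scatter), so a shift of one methoxy group, with the same atoms, is enough to bring a measurable dose into view. The true size of the step cannot be read because compound 2 holds only a limit: the limit of > 20 mg/kg in this assay, at which 3 of the 4 values shown sit.

Going by these compounds, it remains open whether 2-chlorophenyl or 2-ethoxyphenyl on the same amine nitrogen would also give a measurable dose.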